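The source may hold more compounds than are shown below. What is called first, only, known or untested is meant among the compounds shown, and "the series" means these compounds.

Compound 1 `Cc1cnn(C(=O)N2CCCCC2)c1` carries a methyl on its five-membered core, and compound 2 `O=C(N1CCCCC1)n1cccn1` is the same core without that methyl. In an assay on membranes from brain for binding affinity to neutral cholesterol ester hydrolase 1 (Mus musculus), read by fluorescence, with stated times of 1 h and 30 min (a lower number here means a stronger inhibitor, a higher number a weaker inhibitor), compound 1 gives only a limit of the assay, > 100000 nM. In this assay compound 2 likewise gives only a limit, > 100000 nM. The change between them, (hydrogen in place of methyl on an aromatic carbon), thus made a step that cannot be read: a step that the two limits leave unreadable from compound 1 to compound 2. Compound 3 `Cc1cnn(C(=O)N(C)CCN(C)C(c2ccc(OCc3ccccc3)cc2)c2ccc(OCc3ccccc3)cc2)c1` carries the same methyl-bearing ring on a far larger molecule; the difference between the two cores is not broken down here. In this assay compound 3 gives only a limit, > 1000000 nM. Compound 4 `CN(CCN(C)C(c1ccc(OCc2ccccc2)cc1)c1ccc(OCc2ccccc2)cc1)C(=O)n1cccn1` has not been measured. It stands to compound 3 as compound 2 stands to compound 1: hydrogen in place of methyl on an aromatic carbon. The two places are described alike except that the ring atom which in compound 1 bears a group of 8 heavy atoms bears a large group in compound 3, so this is the same kind of change rather than the same change. For the measured compounds named here, with every measured value sitting at a limit, the limit of > 100000 nM in this assay, at which 2 of the 3 values shown sit, and (the limit of > 1000000 nM in this assay, at which 1 of the 3 values shown sits), there is no measured step to lean on. The step that is expected is therefore one of no change, a number no higher from compound 3 to compound 4 (the limit leaves the size open). Compound 4 is estimated at 1000000 nM in this assay, with a range from 100000 nM to 3000000 nM, and it is expected most likely to return only a limit as well.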

Compound 4, half-maximal inhibitory concentration: > 1000000 nM
Compound 4: a limit, no number; the forecaster's own chance of this, stated with the estimate: 90%; the middle value sits exactly at the limit.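

In this assay compound 4 gives > 1000000 nM, which is a limit of the assay and not a number. For the compounds shown here, the step between compound 3 and compound 4 therefore cannot be read, and neither can the one between compound 1 and compound 2. None of the four compounds returns a number, which leaves open whether hydrogen in place of methyl on an aromatic carbon changes inhibition at all.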